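The compounds below may be only part of what the source reports. "The series", "measured", "known", "first", "only" and "open" are said of these compounds alone.

Measured so far in an assay on isolated protein for inhibition of Amine oxidase [flavin-containing] B (Homo sapiens), read by fluorescence, with a stated time of 15 min; on this read-out lower numbers stand for stronger inhibition and higher numbers for weaker inhibition:
- compound 1 `CCOc1ccc2cc(C(=O)/C=C/c3c(/C=C/c4ccc(OC)cc4)cc(OC)cc3OC)c(=O)oc2c1` gives 48100 nM
- compound 2 `COc1ccc(/C=C/c2cc(OC)cc(OC)c2/C=C/C(=O)c2cc3ccc(Br)cc3oc2=O)cc1` gives 55300 nM
- compound 3 `COc1ccc(/C=C/c2cc(OC)cc(OC)c2/C=C/C(=O)c2cc3ccc(OC)cc3oc2=O)cc1` gives 4200 nM

Compound 3 gives the lowest number of the three and is the most potent of the set, with an 11-fold lower number from compound 1 to compound 3 (1.06 log units; beyond the scatter) and a 13-fold lower number from compound 2 to compound 3 (1.12 log units; beyond the scatter) both beyond the scatter. Compound 4 `COc1ccc(/C=C/c2cc(OC)cc(OC)c2/C=C/C(=O)c2cc3ccc(C)cc3oc2=O)cc1` differs from compound 3 by methyl in place of methoxy on an aromatic carbon. Both measured steps bear on this position: bromo, which likewise carries no acceptor, was weaker by a 13-fold lower number from compound 2 to compound 3 (1.12 log units; beyond the scatter), and ethoxy by an 11-fold lower number from compound 1 to compound 3 (1.06 log units; beyond the scatter). A clearly higher number in this assay is therefore expected for compound 4, estimated at 25000 nM (range 8000 nM to 80000 nM), a step of a 6.0-fold higher number from compound 3 to compound 4 (0.77 log units; beyond the scatter).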

Compound 4, half-maximal inhibitory concentration: 2780 nM
Compound 4: the middle estimate sits 9.0-fold (0.95 log units) above what was measured; measured number outside the range, below it.
By their numbers in this assay, from the lowest: compounds 4 and 3 (each within the scatter of the next); then compounds 1 and 2 (each within the scatter of the next).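

Methyl and methoxy are not separated at this aromatic carbon (a 1.5-fold lower number from compound 3 to compound 4 (0.18 log units; within the scatter)), so a hydrogen-bond acceptor on the group here is not required for the lower numbers, as methyl has none. Methyl also stands well clear of bromo (a 20-fold lower number from compound 2 to compound 4 (1.30 log units; beyond the scatter)) and ethoxy (a 17-fold lower number from compound 1 to compound 4 (1.24 log units; beyond the scatter)), which places the sharp divide among the substituents between the two smallest groups and the other two. No evidence on hand accounts for these differences. Still open, going by these compounds, is whether an amine, a hydroxyl or chloro at this place would join methyl and methoxy or bromo and ethoxy. On these data alone, how a longer chain or plain hydrogen would behave is also open.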